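Swapping the chain end on a shared core

The source may report more compounds than this note shows. Statements on the series, on what has been measured and on what is new or still open speak of the compounds shown alone.

Compound 2 `Cn1c(-c2ccccc2C(F)(F)F)nnc1C12CCC(COc3ccc(S(C)(=O)=O)cc3)(CC1)CC2` stands at the top of the two numbers measured in a functional assay on the whole organism (strain ICR) for inhibition, with Mus musculus as the target, with a stated time of 4 h, at a dose of 10 mg/kg by the oral route (on this read-out lower numbers stand for less inhibition and higher numbers for more inhibition at the one dose given (going by the name of the read-out)), where compound 2 gives 79%. Compound 1 `Cn1c(-c2ccccc2C(F)(F)F)nnc1C12CCC(CNS(C)(=O)=O)(CC1)CC2` lies nearest; in this assay compound 1 gives 73%, and the step of a number 6 percentage points higher from compound 1 to compound 2 (within the scatter) sits within the scatter. Compound 3 `CCS(=O)(=O)CCCCC12CCC(c3nnc(-c4ccccc4C(F)(F)F)n3C)(CC1)CC2` differs from compound 2 by 3-(ethylsulfonyl)propyl in place of 4-(methylsulfonyl)phenoxy on a saturated chain carbon bound to a saturated ring carbon. Within the data shown here, the only measured step at this same place, a number 6 percentage points higher from compound 1 to compound 2 (within the scatter), was within the scatter, so no step beyond the scatter is expected here, in either direction; the expected step is a number 6 percentage points lower from compound 2 to compound 3 (within the scatter). Compound 3 is therefore estimated at 73%, with a range from 55% to 88%.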

Compound 3, a percentage reported as inhibition, in the whole organism at one dose (the size of the read-out at that dose, not a potency): 90%
Compound 3: middle estimate off by 17 percentage points, on the low side, and the stated range ends below it.
By their numbers in this assay, from the lowest: compounds 1 and 2 (each within the scatter of the next); then compound 3.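

At this place on a saturated chain carbon bound to a saturated ring carbon, the earlier swap had stayed within the scatter in this assay, so the position had not yet separated any two chain ends. The ring-free 3-(ethylsulfonyl)propyl group now gives a number 11 percentage points higher from compound 2 to compound 3 (beyond the scatter) and a number 17 percentage points higher from compound 1 to compound 3 (beyond the scatter), which shows that the chain end can change this read-out. No measurement shown explains this rise.

From the compounds shown here alone, whether the rise belongs to the ethylsulfonyl end or to the propyl chain carrying it remains open. So does whether a longer chain, or a carboxylic acid at the chain end, would hold it.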